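Removing One Chloro from Compound 2

The compounds below may be only part of what the source reports. "The series", "measured", "known", "first", "only" and "open" are said of these compounds alone.

This account follows a single structural step in a functional assay on the whole organism (S2 cells, strain S2) for inhibition, with Drosophila as the target, read by a luciferase reporter, with stated times of 1.5 h and 8 h; on this read-out higher numbers stand for weaker inhibition and lower numbers for stronger inhibition. Of the compounds shown here, three have been measured so far. Compound 1 `CCCC(=O)c1c(OC)c(Cl)c(OC)c(Cl)c1OC` gives 20800 nM, and compound 3 `CCCC(=O)c1c(O)c(Cl)c(O)c(Cl)c1O` gives 21500 nM. Compound 2 `CCCCCC(=O)c1c(O)c(Cl)c(OC)c(Cl)c1O` gives 4600 nM, the lowest of the three numbers; its gap to compound 1 and its gap to compound 3 both lie beyond the scatter, so compound 2 is the strongest inhibitor in this small set. Compound 4 `CCCCCC(=O)c1c(O)cc(OC)c(Cl)c1O` has not yet been measured. It differs from compound 2 in one place: hydrogen in place of chloro on an aromatic carbon. Going by the values given here, no pair of measured compounds shows this kind of step, so its size is not known from the data at hand. Inhibition is expected to become somewhat weaker with this change, by a step estimated as a 2.2-fold higher number from compound 2 to compound 4 (0.34 log units; beyond the scatter), likely beyond the scatter but not large. Compound 4 is therefore expected to give about 10000 nM in this assay, with a plausible range from 3500 nM to 30000 nM.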

Compound 4, half-maximal inhibitory concentration: 4600 nM
Beside the measured number, compound 4's estimate is 2.2-fold (0.34 log units) above it, within the range that was stated.
By their numbers in this assay, from the lowest: compounds 2 and 4 (each within the scatter of the next); then compounds 1 and 3 (each within the scatter of the next).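

In this assay, hydrogen in place of the chloro ortho to a hydroxy group and ortho to a methoxy group gives no change at the digits printed from compound 2 to compound 4 (within the scatter) and so costs nothing on this read-out. Going by these compounds alone, no two of the earlier compounds differ in one place only, so this is the first direct reading on this position, and it shows that this chloro is not needed for the inhibition seen with compound 2. Nothing in the data at hand explains why the step is so small.

On these data alone, whether the chloro meta to this place could also give way to hydrogen remains open. Equally open, as far as these compounds go, is what a bromo, a methyl or an amine would do on this aromatic carbon.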